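The source may hold more compounds than are shown below. What is called first, only, known or untested is meant among the compounds shown, and "the series" means these compounds.

The three measured compounds are:

compound 1, `CC[C@@H](Nc1c(C#N)c(-c2ccc(-c3cccc(CO)c3)cc2)nc2cnccc12)C(N)=O`, 2
compound 2, `CC[C@@H](Nc1c(C#N)c(-c2ccc(-c3cccc(Cl)c3)cc2)nc2cnccc12)C(N)=O`, 3.1
compound 3, `CC[C@@H](Nc1c(C#N)c(-c2ccc(-c3ccccc3CO)cc2)nc2cnccc12)C(N)=O`, 2.1

All three were run in a physicochemical assay for lipophilicity, read by HPLC, at pH 7.5; a higher number here means a more lipophilic compound, a lower number a more polar compound. Compound 1 and compound 2 differ by one change, (chloro in place of hydroxymethyl on an aromatic carbon), and that change gave a number 1.10 log units higher from compound 1 to compound 2 (beyond the scatter). Compound 1 and compound 3 carry the same atoms joined differently, (2-(hydroxymethyl)phenyl in place of 3-(hydroxymethyl)phenyl on an aromatic carbon), and the step between them, a number 0.10 log units higher from compound 1 to compound 3 (within the scatter), is within the scatter. Between compound 2 and compound 3 the step is a number 1.00 log units lower from compound 2 to compound 3 (beyond the scatter).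

Compound 4, `CC[C@@H](Nc1c(C#N)c(-c2ccc(-c3ccccc3Cl)cc2)nc2cnccc12)C(N)=O`, has not yet been measured in this assay. It differs from compound 3 by chloro in place of hydroxymethyl on an aromatic carbon. Within the data shown here, this is the same kind of change as the one from compound 1 to compound 2, but the two places are not the same: from compound 1 to compound 2 the change sits meta to a large group, while from compound 3 to compound 4 it sits ortho to a large group. The change occurs twice among the compounds shown.

Because the earlier instance gave a number 1.10 log units higher from compound 1 to compound 2 (beyond the scatter), a step of similar size is expected here, and compound 4 is estimated to lie a number 1.10 log units higher from compound 3 to compound 4 (beyond the scatter) from compound 3 in this assay. On that basis compound 4 is expected to give about 3.2 in this assay, with a range from 2.7 to 3.7.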

Compound 4, distribution coefficient: 2.9
The estimate for compound 4 lay 0.30 log units above the measured number, within the range that was stated.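

In this assay the exchange of hydroxymethyl for chloro gave a number 0.80 log units higher from compound 3 to compound 4 (beyond the scatter) and, in its earlier instance, a number 1.10 log units higher from compound 1 to compound 2 (beyond the scatter); both steps run the same way and lie beyond the scatter, so the change kept its direction in going from 3-(hydroxymethyl)phenyl to 3-chlorophenyl and from 2-(hydroxymethyl)phenyl to 2-chlorophenyl. The two chloro compounds cannot be told apart, since the step of a number 0.20 log units lower from compound 2 to compound 4 (within the scatter) is within the scatter, while the step of a number 0.90 log units higher from compound 1 to compound 4 (beyond the scatter) lies beyond it, although that step also moves the substituent as well as exchanging it. These two instances show agreement in direction on one shared core only; they do not show that the step would hold on a different core, and nothing available explains its size.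

The compounds shown leave open whether the step would look the same with an amine, a carboxylic acid or a longer chain such as hydroxyethyl in place of chloro. They also leave open how the exchange would behave on a phenyl ring bearing a second substituent, or with a group other than the butanamide side chain on the shared core.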